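Returning to the dihydroxypropyl group on the shared core

A few compounds are considered here, and "the series" means these few. Any claim that something is new, unique, unknown or untested is made for them only; others in the source may bear on it.

Measured in a functional assay on MCF7 cells (Homo sapiens) for cytotoxicity, read by MTT assay, with a stated time of 72 h; on this read-out lower numbers stand for stronger inhibition and higher numbers for weaker inhibition:
- compound 1 `O=C1c2c[n+]([O-])c3ccccc3c2C(=O)c2c1c1ccccc1n2Cc1cn([C@@H]2C[C@H](O)[C@@H](CO)O2)nn1`: 110 nM
- compound 2 `O=C1c2c[n+]([O-])c3ccccc3c2C(=O)c2c1c1ccccc1n2Cc1cn(CC(O)CO)nn1`: 1110 nM
- compound 3 `CN1CCN(CCCCCCn2c3c(c4ccccc42)C(=O)c2c[n+]([O-])c4ccccc4c2C3=O)CC1`: 400 nM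

Compound 3 holds the second highest of the three numbers, with compound 2 nearest and compound 1 furthest. Compound 4 `O=C1c2c[n+]([O-])c3ccccc3c2C(=O)c2c1c1ccccc1n2Cc1cn(C[C@@H](O)CO)nn1` differs from it as follows: 1-(2,3-dihydroxypropyl)-1H-1,2,3-triazol-4-yl in place of 5-(4-methylpiperazin-1-yl)pentyl on a saturated chain carbon bound to an aromatic nitrogen. Thus 1-(2,3-dihydroxypropyl)-1H-1,2,3-triazol-4-yl comes in place of 5-(4-methylpiperazin-1-yl)pentyl on a saturated chain carbon bound to an aromatic nitrogen. The measured step bearing most directly is a 2.8-fold lower number from compound 2 to compound 3 (0.44 log units; beyond the scatter), the same exchange in the opposite direction, since compound 4 carries the group of compound 2 with its stereocentre defined. The step of a 10-fold higher number from compound 1 to compound 2 (1.00 log units; beyond the scatter) is a different exchange and bears less. A modest rise of similar size is therefore expected in this assay. The expected step is a 2.5-fold higher number from compound 3 to compound 4 (0.40 log units; beyond the scatter). Compound 4 is estimated at 1000 nM, with an expected range of 500 nM to 2200 nM.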

Compound 4, half-maximal inhibitory concentration: 600 nM
The estimate for compound 4 lay 1.7-fold (0.22 log units) above the measured number; the range from low to high includes it.
By their numbers in this assay, from the lowest: compound 1; then compounds 3, 4 and 2 (each within the scatter of the next, the first and the last beyond it).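

In this assay the exchange at this position now reads a 1.5-fold higher number from compound 3 to compound 4 (0.18 log units; within the scatter), so the gap seen between compound 2 and compound 3 does not recur with the stereocentre defined. Going by these compounds alone, the step of a 1.9-fold lower number from compound 2 to compound 4 (0.27 log units; within the scatter) also lies within the scatter, and only one thing separates that pair: the fact that one of compounds 2 and 4 is drawn with a defined configuration and the other without, at the place where they differ. The step of a 5.5-fold higher number from compound 1 to compound 4 (0.74 log units; beyond the scatter) shows that the 4-hydroxy-5-(hydroxymethyl)oxolan-2-yl group still gives the lower number against 2,3-dihydroxypropyl of defined configuration.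

The compounds shown leave open how the opposite configuration of the 2,3-dihydroxypropyl group would read. They also leave open what a primary amine or a carboxylic acid would give in its place.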